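This account rests on a few compounds, and the source may have more. Where it says the series, first, only, none or still open, it means among the compounds named here.

In a functional assay on CAKI-1 cells (Homo sapiens) for cytotoxicity, read by sulforhodamine B assay, with a stated time of 48 h, tested at 100 uM (on this read-out higher numbers stand for a weaker effect at the one concentration tested and lower numbers for a stronger effect), compound 2 `COc1ccc(C(=O)/C=C/c2cc(-c3cc(OC)c(OC)c(OC)c3)n[nH]2)cc1OC` gives -91%, the lowest of the two numbers recorded. Compound 1 `COc1ccc(-c2cc(/C=C/C(=O)c3ccc(N)cc3)[nH]n2)cc1` gives -63% in this assay, a number higher than that of compound 2 by a margin beyond the scatter. Compound 3 `COc1cc(-c2cc(/C=C/C(=O)c3ccc(F)c(F)c3)[nH]n2)cc(OC)c1OC` has not yet been measured; it differs from compound 2 by 3,4-difluorophenyl in place of 3,4-dimethoxyphenyl on a carbonyl carbon. Among the compounds with values here, no measured pair shows this change, so the step it brings in this assay can only be estimated. Compound 3 is expected to show a somewhat higher number, a step of a number 16 percentage points higher from compound 2 to compound 3 (beyond the scatter) from compound 2. Compound 3 is thus estimated at -75%, within a range from -100% to -45%.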

Compound 3, a percentage reported as activity, at one concentration (the size of the read-out at that concentration, not a potency): 3%
For compound 3 the middle estimate is 78 percentage points below the measured one, and the stated range ends below it.
By their numbers in this assay, from the lowest: compound 2; then compound 1; then compound 3.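

In this assay, the group on this carbonyl carbon matters greatly: 3,4-difluorophenyl in place of 3,4-dimethoxyphenyl gives a number 94 percentage points higher from compound 2 to compound 3 (beyond the scatter). At the one concentration tested, the strong effect of compound 2 therefore does not survive this change, although the aromatic ring of carbon stays in place and only its substituents differ. No measurement at hand explains this loss. As far as these compounds go, whether the effect needs both methoxy groups remains open, as does how a hydroxyl group or a carboxylic acid on this ring would fare.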